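This account rests on a few compounds, and the source may have more. Where it says the series, first, only, none or still open, it means among the compounds named here.

For the measured compounds named here, in a functional assay on MOLT-4 cells (Homo sapiens) for antiproliferative activity, read by MTT assay, with a stated time of 48 h (on this read-out lower numbers stand for stronger inhibition and higher numbers for weaker inhibition), three compounds have numbers so far. Compound 1 `O=C(/C=C/c1ccc(Cn2cc(Nc3ncc(Cl)c(Nc4ccc(F)cc4)n3)cn2)cc1)NO` gives 330 nM, compound 2 `O=C(CCCCCCn1cc(Nc2ncc(Cl)c(Nc3cccc(Cl)c3)n2)cn1)NO` gives 130 nM, and compound 3 `O=C(CCCCCn1cc(Nc2ncc(Cl)c(Nc3ccc(F)cc3)n2)cn1)NO` gives 120 nM. Compound 2 thus lies within the scatter of compound 3, while its number is lower than that of compound 1 by more than the scatter. Compound 4 `O=C(CCCCCCn1cc(Nc2ncc(Cl)c(NC3CC3)n2)cn1)NO` departs from compound 2 in one place, with cyclopropyl in place of 3-chlorophenyl on a nitrogen on an aromatic ring. Going by the values given here, no measured pair shows this change, so any forecast is uncertain, but a moderate shift towards weaker inhibition in this assay is expected. The expected change is a 2.3-fold higher number from compound 2 to compound 4 (0.36 log units; beyond the scatter). For compound 4 the estimated value is 300 nM, with an expected range from 100 nM to 900 nM.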

Compound 4, half-maximal inhibitory concentration: 150 nM
Beside the measured number, compound 4's estimate is 2.0-fold (0.30 log units) above it; the measured number falls inside the stated range.
By their numbers in this assay, from the lowest: compounds 3, 2 and 4 (each within the scatter of the next); then compound 1.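

In this assay, for the compounds shown here, the first step at this position shows that cyclopropyl can stand in place of 3-chlorophenyl on a nitrogen on an aromatic ring with a 1.2-fold higher number from compound 2 to compound 4 (0.06 log units; within the scatter). In this one pair, then, the six-membered aromatic ring is not needed to keep the number, and 3 heavy atoms serve as well as 7. Nothing available accounts for this result.

As far as these compounds go, whether other groups at this position, such as a morpholine, a plain methylamino group or a longer alkyl chain, would also keep the number remains open. Also open, from the compounds shown here alone, is whether the same change would behave alike on a different chain.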